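Swapping Methoxy for Cyano on a Weak Thiourea

The compounds below may be only part of what the source reports. "The series", "measured", "known", "first", "only" and "open" are said of these compounds alone.

Compound 1, `COc1ccc(NC(=S)NC2CC(C)(C)Oc3ccc(Br)cc32)cc1`, was tested in a functional assay on U-373MG ATCC cells (Homo sapiens) for inhibition, read by MTT assay, with a stated time of 72 h (on this read-out higher numbers stand for weaker inhibition and lower numbers for stronger inhibition), where compound 1 gives 40000 nM. That is the highest of the two numbers recorded here, so compound 1 is the weaker of the two. Its only companion, compound 2, `CC1(C)CC(NC(=O)Nc2ccccc2Cl)c2cc(Br)ccc2O1`, gives in this assay a value of 19000 nM, a lower number than that of compound 1, and the gap between them lies beyond the usual scatter. For the measured compounds named here, compound 3, `CC1(C)CC(NC(=S)Nc2ccc(C#N)cc2)c2cc(Br)ccc2O1`, keeps the thiourea of compound 1 and changes only one group: cyano in place of methoxy on an aromatic carbon. Going by the values given here, no measured pair isolates this change, so the size of the step is uncertain. Both known numbers sit in a weak range, and nothing in the data points to a large shift in either direction; a step within the scatter, or a slightly lower number, seems the most plausible outcome. Compound 3 is therefore expected to land at about 30000 nM, with a range from 10000 nM to 80000 nM, which means an expected step of a 1.3-fold lower number from compound 1 to compound 3 (0.12 log units; within the scatter) in this assay.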

Compound 3, half-maximal inhibitory concentration: 22000 nM
The estimate for compound 3 lay 1.4-fold (0.13 log units) above the measured number; low and high end bracket the measured number.
By their numbers in this assay, from the lowest: compounds 2, 3 and 1 (each within the scatter of the next, the first and the last beyond it).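

Going from the 4-methoxyphenyl to the 4-cyanophenyl group, with the thiourea and the rest of compound 1 kept, gives a 1.8-fold lower number from compound 1 to compound 3 (0.26 log units; within the scatter) in this assay, so this single change produces no readable shift in the number. For the compounds shown here, this is the first direct view of this position, on an aromatic carbon para to a large group: methoxy and cyano each bring two heavy atoms and one hydrogen-bond acceptor, and this exchange leaves the compound in the same weak range. No measurement here offers an explanation for this result.

From the compounds shown here alone, the pair says nothing about whether an amine or a carboxylic acid in this place would move the number beyond the usual scatter, so the reach of this tolerance beyond methoxy and cyano remains unknown. Compound 2 differs from compound 3 in more than one place, which leaves open how the thiourea compares with the urea when the aromatic ring carries the same group.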